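The source may report more compounds than this note shows. Statements on the series, on what has been measured and on what is new or still open speak of the compounds shown alone.

In a functional assay on DU-145 cells (Homo sapiens) for inhibition, read by trypan blue exclusion, with a stated time of 96 h (a higher number here means a weaker inhibitor of growth, a lower number a stronger inhibitor of growth), compound 3 `CN(C)c1ccc(/C=C(/Sc2ccccc2Br)C(=O)c2ccc(Br)cc2)cc1` gives > 100000 nM, which is a limit and not a number. Compound 4 `CN(C)c1ccc(/C=C(/SCc2ccc(F)cc2)C(=O)c2ccc(Br)cc2)cc1` has 4-fluorobenzyl in place of 2-bromophenyl on a sulfur. Going by the values given here, no measured step isolates this change. The nearest evidence comes from two compounds that already carry 4-fluorobenzyl on the sulfur: compound 1 `Cc1cc(C)cc(/C=C(/SCc2ccc(F)cc2)C(=O)c2ccc(Br)cc2)c1` gives 10000 nM and compound 2 `COc1ccccc1/C=C(/SCc1ccc(F)cc1)C(=O)c1ccc(Br)cc1` gives 10000 nM. The step between them, no change at the digits printed from compound 1 to compound 2 (within the scatter), suggests tolerance of a change at the other end of the molecule. The expected step is an at least 10-fold lower number from compound 3 to compound 4 (1.00 log units; beyond the scatter), towards stronger growth inhibition in this assay. For compound 4 the estimate is 10000 nM, with an expected range of 2500 nM to 50000 nM.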

Compound 4, concentration for 50% growth inhibition: 50000 nM
Estimate against measurement, compound 4: 5.0-fold (0.70 log units) below, and the stated range covers the measured number.
By their numbers in this assay, from the lowest: compounds 1 and 2 (each within the scatter of the next); then compound 4. At a limit, above all of these: compound 3.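

Compound 3 stands at a limit, not a number: the limit of > 100000 nM in this assay, at which 1 of the 4 values shown sits. In this assay, 4-fluorobenzyl on the sulfur gives an at least 2.0-fold lower number from compound 3 to compound 4 (0.30 log units; that floor lies within the scatter), a floor only, so the true size of this change remains unfixed. With 4-fluorobenzyl held constant, 4-(dimethylamino)phenyl on the double-bonded chain carbon gives a 5.0-fold higher number from compound 2 to compound 4 (0.70 log units; beyond the scatter) and a 5.0-fold higher number from compound 1 to compound 4 (0.70 log units; beyond the scatter), so the tolerance seen earlier at this end does not extend to this group.

Open, from the compounds shown here alone, is how a plain benzyl or a 2-bromobenzyl on the sulfur would read, which would separate the chain carbon from the ring substituent. Also open, going by these compounds, is how a morpholine in place of the dimethylamino group would read.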